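The compounds below may be only part of what the source reports. "The series", "measured", "known", "first", "only" and "open" are said of these compounds alone.

Going by the values given here, in a functional assay on DU-145 cells (Homo sapiens) for cytotoxicity, read by MTT assay (a higher number here means a weaker inhibitor, a lower number a stronger inhibitor), three compounds sharing one core have numbers so far. Compound 1 `CCCC(O)CC(=O)O[C@H](CC=C(C)C)C1=CC(=O)c2c(O)ccc(O)c2C1=O` gives only a limit, > 100000 nM. Compound 2 `CCCCC(CC(=O)O[C@H](CC=C(C)C)C1=CC(=O)c2c(O)ccc(O)c2C1=O)OC(C)=O` gives 67700 nM, and compound 3 `CC(C)=CC[C@@H](OCCO)C1=CC(=O)c2c(O)ccc(O)c2C1=O` gives 9900 nM, the lowest number of the three.

The next compound, compound 4 `CC(C)=CC[C@@H](OC(=O)C1CCCOC1)C1=CC(=O)c2c(O)ccc(O)c2C1=O`, changes compound 3 at one place: (oxan-3-yl)carbonyl in place of 2-hydroxyethyl on an oxygen on a saturated carbon, ((oxan-3-yl)carbonyl in place of 2-hydroxyethyl on an oxygen on a saturated carbon).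

Among the compounds with values here, two measured steps bear on this. The closest is an at least 10-fold lower number from compound 1 to compound 3 (1.00 log units; beyond the scatter), where 2-hydroxyethyl replaced (2-hydroxypentyl)carbonyl on the same oxygen, a change beyond the scatter. The new change runs the opposite way, putting a carbonyl-linked group back on that oxygen. The other is an at least 1.4-fold lower number from compound 1 to compound 2 (0.16 log units; that floor lies within the scatter), a change within the carbonyl-linked group that left compound 2 still well above compound 3. Neither of these compounds carries the oxan-3-yl ring, so the size remains uncertain.

The expected change is a 3.0-fold higher number from compound 3 to compound 4 (0.48 log units; beyond the scatter), towards a weaker inhibitor. The estimate for compound 4 is 30000 nM, with an expected range from 8000 nM to 100000 nM.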

Compound 4, half-maximal inhibitory concentration: 29700 nM
Compound 4: middle estimate off by 1.0-fold (0.00 log units), on the high side; the measured number falls inside the stated range.
By their numbers in this assay, from the lowest: compound 3; then compound 4; then compound 2. At a limit, above all of these: compound 1.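

In this assay, a 3.0-fold higher number from compound 3 to compound 4 (0.48 log units; beyond the scatter), so this ring-bearing carbonyl group on the oxygen gives a weaker inhibitor than the small 2-hydroxyethyl group. Among the carbonyl-linked groups, however, the ring gives the lower numbers, with a 2.3-fold lower number from compound 2 to compound 4 (0.36 log units; beyond the scatter) and an at least 3.3-fold lower number from compound 1 to compound 4 (0.52 log units; beyond the scatter). Compound 1 gives only a limit, so its step is a floor and not a measured size: the limit of > 100000 nM in this assay, at which 1 of the 4 values shown sits.

Still open is whether the lower number of compound 4 among these carbonyl-linked groups depends on the ring oxygen, which a cyclohexylcarbonyl group on the same oxygen could test. Also open, as far as these compounds go, is how a 2-aminoethyl group there would compare with 2-hydroxyethyl.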